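This account rests on a few compounds, and the source may have more. Where it says the series, first, only, none or still open, it means among the compounds named here.

Measured compounds:
- compound 1, `O=C(/C=C/c1ccccc1)c1cccc(NC(=O)c2cc(-c3ccncc3)n[nH]2)c1`: 67100 nM in a functional assay, read by spectrophotometry, tested at 100 uM; on this read-out higher numbers stand for weaker inhibition and lower numbers for stronger inhibition
- compound 2, `O=C(/C=C/c1cccc2ccccc12)c1cccc(NC(=O)c2cc(-c3ccncc3)n[nH]2)c1`: 64500 nM in this assay

Compound 1 gives the higher of the two numbers recorded so far, though its gap to compound 2 is small: the step of a 1.0-fold lower number from compound 1 to compound 2 (0.02 log units; within the scatter) is within the scatter, so the two values cannot be told apart with any confidence. Compound 3, `O=C(/C=C/c1ccc(Cl)cc1Cl)c1cccc(NC(=O)c2cc(-c3ccncc3)n[nH]2)c1`, has not yet been measured. It shares the core of compound 1 and differs from it in one place only: 2,4-dichlorophenyl in place of phenyl on a double-bonded chain carbon bound to a double-bonded chain carbon.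

Among the compounds with values here, the only measured step that bears on this change is the one from compound 1 to compound 2, where a larger aromatic group replaced the phenyl at the same place and the number did not move beyond the scatter. Within the data shown here, no measured step tests the effect of chlorine substitution on this phenyl, so the expectation rests on that single step alone. On that basis, no step beyond the scatter is expected, and compound 3 is expected to give 60000 nM, in the range 25000 nM to 150000 nM, which means an estimated step of a 1.1-fold lower number from compound 1 to compound 3 (0.05 log units; within the scatter).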

Compound 3, half-maximal inhibitory concentration: 35000 nM
For compound 3 the middle estimate is 1.7-fold (0.23 log units) above the measured one, within the range that was stated.
By their numbers in this assay, from the lowest: compounds 3, 2 and 1 (each within the scatter of the next).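

The new compound is the first shown with chlorine on this ring. In this assay the change from phenyl to 2,4-dichlorophenyl, on a double-bonded chain carbon bound to a double-bonded chain carbon, gives a 1.9-fold lower number from compound 1 to compound 3 (0.28 log units; within the scatter) and so does not separate the two compounds. Compared with the larger naphthalen-1-yl group at the same place, 2,4-dichlorophenyl gives a 1.8-fold lower number from compound 2 to compound 3 (0.27 log units; within the scatter) and this pair cannot be told apart either, so the three different ring groups shown here give values that lie within the usual spread of repeat measurements. No separate measurement is available that could explain these small differences in the numbers.

The compounds shown leave open whether an amine or a carboxylic acid on this phenyl, in place of the two chlorine atoms, would move the number beyond the scatter. They also leave open whether a single chlorine would give a value any different from that of the 2,4-dichlorophenyl group, and whether a change to the shared core would matter more than one at this place.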